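A Bulkier Chain End: What Compound 4 Might Show

This account rests on a few compounds, and the source may have more. Where it says the series, first, only, none or still open, it means among the compounds named here.

Three measured compounds share one core and differ only in the group carried by the saturated chain carbon bound to the amide-type nitrogen. In an assay on membranes from Sf9 cells for displacement of a labelled ligand from histamine H2 receptor (Homo sapiens), read by scintillation counting, with a stated time of 60 min (a higher number here means a weaker inhibitor, a lower number a stronger inhibitor), compound 1 `CCCNC(=O)/N=C(\N)NCCCc1sc(N)nc1C` gives 105 nM. Compound 2 `Cc1nc(N)sc1CCCN/C(N)=N/C(=O)NCc1ccco1` gives 10.5 nM in this assay, and compound 3 `CCCCCCNC(=O)/N=C(\N)NCCCc1sc(N)nc1C` gives 28.8 nM. Compound 3 therefore holds the second highest of the three numbers; the steps that place it are a 3.6-fold lower number from compound 1 to compound 3 (0.56 log units; beyond the scatter) and a 2.7-fold higher number from compound 2 to compound 3 (0.44 log units; beyond the scatter), both beyond the usual scatter but modest in size.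

Compound 4 `Cc1nc(N)sc1CCCN/C(N)=N/C(=O)NCC(C)C1CCCCC1` has not yet been measured in this assay. It differs from compound 3 by 1-cyclohexylethyl in place of pentyl on a saturated chain carbon bound to an amide-type nitrogen. Among the measured compounds shown here, two measured steps bear on this place on the chain: a 3.6-fold lower number from compound 1 to compound 3 (0.56 log units; beyond the scatter), where more carbon on the chain lowered the number, and a 2.7-fold higher number from compound 2 to compound 3 (0.44 log units; beyond the scatter), where a ring at the chain end was tied to the lower number. Both point the same way, so a modest lowering rather than no change is the more likely outcome for compound 4.

Compound 4 is therefore expected to give about 14 nM in this assay, with a likely range from 5 nM to 45 nM. That estimate corresponds to an expected step of a 2.1-fold lower number from compound 3 to compound 4 (0.31 log units; beyond the scatter).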

Compound 4, inhibition constant: 39.8 nM
For compound 4 the middle estimate is 2.8-fold (0.45 log units) below the measured one, and the stated range covers the measured number.
By their numbers in this assay, from the lowest: compound 2; then compounds 3 and 4 (each within the scatter of the next); then compound 1.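

In this assay, 1-cyclohexylethyl in place of pentyl on a saturated chain carbon bound to an amide-type nitrogen gives a 1.4-fold higher number from compound 3 to compound 4 (0.14 log units; within the scatter), so at this position the carbon-only six-membered ring cannot be told apart from the open pentyl chain. A ring at the chain end is therefore not enough to reach the number of compound 2: the step is a 3.8-fold higher number from compound 2 to compound 4 (0.58 log units; beyond the scatter), which sets the saturated ring of compound 4 apart from furan-2-yl, while the comparison with the shorter chain of compound 1 still shows a 2.6-fold lower number from compound 1 to compound 4 (0.42 log units; beyond the scatter) as the all-carbon group grows. Nothing given here accounts for these differences.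

The compounds shown do not tell whether a phenyl or thiophene ring in place of furan-2-yl would stay as low as compound 2, or whether the number depends on the furan oxygen. They also leave open what a plain cyclohexylmethyl group without the branching methyl, or an amine or hydroxyl on the cyclohexyl ring, would do at this position.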